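A few compounds are considered here, and "the series" means these few. Any claim that something is new, unique, unknown or untested is made for them only; others in the source may bear on it.

Of the compounds shown here, three sharing one core have been measured in a functional assay on A549 cells (Homo sapiens) for inhibition, read by MTT assay, with a stated time of 24 h; a higher number here means a weaker inhibitor, a lower number a stronger inhibitor. Compound 1 `CC1(C)[C@H]2CC[C@]1(C)N(Cc1cn(-c3cccc(Cl)c3)nn1)C(=O)C2` gives 60 nM, compound 2 `Cc1ccccc1-n1cc(CN2C(=O)C[C@@H]3CC[C@@]2(C)C3(C)C)nn1` gives 90 nM, and compound 3 `CC1(C)[C@H]2CC[C@]1(C)N(Cc1cn(-c3ccccc3O)nn1)C(=O)C2` gives 230 nM. Compound 3 therefore stands at the highest of the three numbers: the step of a 3.8-fold higher number from compound 1 to compound 3 (0.58 log units; beyond the scatter) and the step of a 2.6-fold higher number from compound 2 to compound 3 (0.41 log units; beyond the scatter) both lie beyond the scatter, while the step of a 1.5-fold higher number from compound 1 to compound 2 (0.18 log units; within the scatter) does not.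

The next compound, compound 4 `COc1ccccc1-n1cc(CN2C(=O)C[C@@H]3CC[C@@]2(C)C3(C)C)nn1`, differs from compound 3 in one place: methyl in place of hydrogen on an oxygen on an aromatic ring. Among the measured compounds shown here, no measured step covers this exact change, a methyl placed on the oxygen of the hydroxy group. The nearest guide is the step of a 2.6-fold higher number from compound 2 to compound 3 (0.41 log units; beyond the scatter), in which hydroxy replaced methyl on an aromatic carbon and the number rose modestly. A methoxy group shares its carbon count with the methyl of compound 2 while keeping the oxygen of compound 3, so the two measured neighbours bracket the expectation: a number no higher than that of compound 3 and possibly closer to that of compound 2.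

On that basis compound 4 is expected to give 130 nM in this assay, within a range of 55 nM to 310 nM, which corresponds to an expected step of a 1.8-fold lower number from compound 3 to compound 4 (0.25 log units; within the scatter).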

Compound 4, half-maximal inhibitory concentration: 350 nM
Beside the measured number, compound 4's estimate is 2.7-fold (0.43 log units) below it, outside the stated range (above it).
By their numbers in this assay, from the lowest: compounds 1 and 2 (each within the scatter of the next); then compounds 3 and 4 (each within the scatter of the next).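

In this assay, methyl in place of hydrogen on the oxygen gives a 1.5-fold higher number from compound 3 to compound 4 (0.18 log units; within the scatter), so the hydroxy hydrogen alone does not separate compound 3 from the two compounds with lower numbers. The oxygen-bearing pattern holds when that hydrogen is replaced: methoxy in place of methyl gives a 3.9-fold higher number from compound 2 to compound 4 (0.59 log units; beyond the scatter), and 2-methoxyphenyl in place of 3-chlorophenyl gives a 5.8-fold higher number from compound 1 to compound 4 (0.77 log units; beyond the scatter), both beyond the scatter. Among these four compounds, the 2-hydroxyphenyl and 2-methoxyphenyl groups therefore stand together at the higher numbers, the 2-methylphenyl and 3-chlorophenyl groups stand together at the lower numbers, and no compound shown goes against this split.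

Nothing available explains why the two oxygen-bearing compounds give the higher numbers. The compounds shown also leave open whether a longer chain on the oxygen, such as ethyl, would stay within the scatter of compound 4, and whether an amine or a fluorine in place of the hydroxy group would fall with compound 3 and compound 4 or with compound 1 and compound 2.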